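Replacing the ortho fluorine aryl urea with an isopropyl aryl urea

This account rests on a few compounds, and the source may have more. Where it says the series, first, only, none or still open, it means among the compounds named here.

Compound 1, `Nc1n[nH]c2cccc(-c3cccc(NC(=O)Nc4ccccc4F)c3)c12`, in a functional assay on A549 cells (Homo sapiens) for inhibition, read by MTT assay, with a stated time of 48 h; on this read-out lower numbers stand for stronger inhibition and higher numbers for weaker inhibition: 1170 nM
Compound 2, `COc1cccc(NC(=O)Nc2cccc(-c3cccc4[nH]nc(N)c34)c2)c1`, in this assay: 2490 nM
Compound 3, `Cc1ccc(NC(=O)Nc2cccc(-c3cccc4[nH]nc(N)c34)c2)cc1Cl`, in this assay: 1750 nM

All three share one core, a urea whose far nitrogen carries a varying aryl group. Compound 1 has the lowest of the three numbers. Its gap to compound 3 is a 1.5-fold higher number from compound 1 to compound 3 (0.17 log units; within the scatter), which lies within the scatter, so the two cannot be ranked; its gap to compound 2 is a 2.1-fold higher number from compound 1 to compound 2 (0.33 log units; beyond the scatter), a modest step beyond the scatter. Between compound 2 and compound 3 the step is a 1.4-fold lower number from compound 2 to compound 3 (0.15 log units; within the scatter), again within the scatter.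

Compound 4, `CC(C)c1cccc(NC(=O)Nc2cccc(-c3cccc4[nH]nc(N)c34)c2)c1`, has not yet been measured. It differs from compound 1 in one place: 3-isopropylphenyl in place of 2-fluorophenyl on an amide-type nitrogen. Both measured swaps of that aryl group away from 2-fluorophenyl gave a higher number in this assay, one modest and one within the scatter. A 3-isopropylphenyl group has not been tried, so the nearest guide is that pair of steps. The number for compound 4 is therefore expected to sit a little above compound 1, with a step of about a 1.5-fold higher number from compound 1 to compound 4 (0.19 log units; within the scatter), and the estimate for compound 4 is 1800 nM, within a range from 900 nM to 3600 nM.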

Compound 4, half-maximal inhibitory concentration: 1420 nM
The estimate for compound 4 lay 1.3-fold (0.10 log units) above the measured number; the range from low to high includes it.
By their numbers in this assay, from the lowest: compounds 1, 4, 3 and 2 (each within the scatter of the next, the first and the last beyond it).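

In this assay, the 3-isopropylphenyl group, whose substituent is all carbon, can take the place of 2-fluorophenyl on this amide-type nitrogen with no change that can be told from the scatter: a 1.2-fold higher number from compound 1 to compound 4 (0.08 log units; within the scatter). The same holds when it replaces the halogen-bearing 3-chloro-4-methylphenyl group, a 1.2-fold lower number from compound 3 to compound 4 (0.09 log units; within the scatter), and when isopropyl replaces methoxy on an aromatic carbon, a 1.8-fold lower number from compound 2 to compound 4 (0.24 log units; within the scatter), so neither fluorine, chlorine nor oxygen on this aryl ring is needed for a number in this range. Compound 4 thus lies within the scatter of each of the other three, even though compound 1 and compound 2 lie beyond the scatter of each other, and nothing available explains why these different groups give such similar numbers.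

On these data alone, all four compounds carry a substituted phenyl group at this position, so it remains open whether an unsubstituted phenyl, a saturated ring such as cyclohexyl, or a phenyl bearing an amine or a carboxylic acid would move the number clearly outside this range. The compounds also leave open how far the isopropyl group's effect depends on where it sits on the ring, since no 2-isopropylphenyl or 4-isopropylphenyl partner is shown.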